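Compound 3 to compound 4: a phenyl swap

The source may hold more compounds than are shown below. What is called first, only, known or untested is meant among the compounds shown, and "the series" means these compounds.

Compound 1 `COc1ccc(C(=O)/C=C/c2ccc(N(C)C)cc2)c2c1C=CC(C)(C)O2`: 1920 nM
Compound 2 `COc1ccc(C(=O)/C=C/c2ccc(Cl)c(Cl)c2)c2c1C=CC(C)(C)O2`: 9440 nM
Compound 3 `COc1ccccc1/C=C/C(=O)c1ccc(OC)c2c1OC(C)(C)C=C2`: > 10000 nM

All three compounds were tested in a functional assay on HCT-116 cells (Homo sapiens) for antiproliferative activity, read by MTT assay, with a stated time of 24 h; a higher number here means a weaker inhibitor, a lower number a stronger inhibitor. Compound 3 sits at the limit of > 10000 nM in this assay, at which 1 of the 3 values shown sits, and that is a limit and not a number.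

Among the measured compounds shown here, compound 4 `COc1ccc(C(=O)/C=C/c2cccc(O)c2)c2c1C=CC(C)(C)O2` has no measurement yet. It differs from compound 3 as follows: 3-hydroxyphenyl in place of 2-methoxyphenyl on a double-bonded chain carbon bound to a double-bonded chain carbon. In words, 3-hydroxyphenyl stands in place of 2-methoxyphenyl on a double-bonded chain carbon bound to a double-bonded chain carbon.

Three measured steps at this same place bear on the change. Two lie beyond the scatter: a 4.9-fold higher number from compound 1 to compound 2 (0.69 log units; beyond the scatter), and an at least 5.2-fold higher number from compound 1 to compound 3 (0.71 log units; beyond the scatter). Both of these leave the 4-(dimethylamino)phenyl group of compound 1, which plays no part in the new change. The third, an at least 1.0-fold higher number from compound 2 to compound 3 (0.02 log units; that floor lies within the scatter), has a floor within the scatter. The closer guide is therefore compound 2 with 9440 nM, and compound 4 is expected to fall in that region of this assay. The expected step is an at least 1.4-fold lower number from compound 3 to compound 4 (0.15 log units; that floor lies within the scatter), toward a lower number and not clearly beyond the scatter. Compound 4 is estimated at 7000 nM, with an expected range from 2500 nM to 16000 nM.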

Compound 4, half-maximal inhibitory concentration: > 10000 nM
Compound 4: only a limit was reported; the forecaster's own chance of this, stated with the estimate: 35%; middle value at least 1.4-fold (0.15 log units) away from the limit.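

In this assay the 3-hydroxyphenyl group brings a hydrogen-bond donor that the 2-methoxyphenyl group lacks, yet it does not bring the reading back toward that of compound 1: the result is an at least 5.2-fold higher number from compound 1 to compound 4 (0.71 log units; beyond the scatter). Against the 3,4-dichlorophenyl group the result is an at least 1.0-fold higher number from compound 2 to compound 4 (0.02 log units; that floor lies within the scatter), so these two groups cannot be told apart at this place on the present readings. The step between compound 3 and compound 4 cannot be read, as both values are limits and not numbers, and compound 4 now stands with compound 3 at that limit: the limit of > 10000 nM in this assay, at which 2 of the 4 values shown sit.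

Going by these compounds, how far past the limit compound 3 and compound 4 lie stays open, and with it any order between the 2-methoxyphenyl and 3-hydroxyphenyl groups. Also open, on these data alone, is whether a 4-aminophenyl or a 4-hydroxyphenyl group on this double-bonded chain carbon would read like compound 1, which would tie its stronger reading to the position of the substituent, or like compound 4.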